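Trifluoromethyl for tert-butyl on the shared core

This account rests on a few compounds, and the source may have more. Where it says the series, first, only, none or still open, it means among the compounds named here.

Compound 1, `Cc1nc2cc(OC[C@H](O)CN3CCN(Cc4nc(-c5ccc(C(C)(C)C)cc5)no4)CC3)ccc2s1`: 570 nM
Compound 2, `Cc1nc2cc(OC[C@H](O)CN3CCN(Cc4nc(-c5ccc(C(C)C)cc5)no4)CC3)ccc2s1`: 1230 nM
Compound 3, `Cc1nc2cc(OC[C@H](O)CN3CCN(Cc4nnc(-c5ccc(C(C)(C)C)cc5)o4)CC3)ccc2s1`: 1100 nM

Three compounds measured in a functional assay on mitochondria from heart for inhibition of peroxisomal acyl-coenzyme A oxidase 1 (Rattus norvegicus) (a higher number here means a weaker inhibitor, a lower number a stronger inhibitor), share one core and differ only at the outer end of the molecule. Compound 1 gives 570 nM, compound 2 gives 1230 nM and compound 3 gives 1100 nM. Compound 3 holds the second highest number of the three, but its gap to compound 2 and its gap to compound 1 both lie within the scatter, so its standing among them cannot be fixed more closely than that.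

Compound 4, `Cc1nc2cc(OC[C@H](O)CN3CCN(Cc4nnc(-c5ccc(C(F)(F)F)cc5)o4)CC3)ccc2s1`, differs from compound 3 by trifluoromethyl in place of tert-butyl on an aromatic carbon. Among the compounds with values here, only one measured step touches that same group: a 2.2-fold higher number from compound 1 to compound 2 (0.33 log units; beyond the scatter), a modest weakening when the tert-butyl was trimmed by one methyl. Within the data shown here, no measured pair involves a trifluoromethyl group, so the size of the present change has to be guessed from that single step. A shift of similar size, towards a weaker inhibitor, seems the most reasonable expectation, with wide uncertainty.

Compound 4 is therefore expected to give 2000 nM, within a range from 800 nM to 5000 nM, an expected step of a 1.8-fold higher number from compound 3 to compound 4 (0.26 log units; within the scatter).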

Compound 4, half-maximal inhibitory concentration: 4800 nM
For compound 4 the middle estimate is 2.4-fold (0.38 log units) below the measured one, and the stated range covers the measured number.
By their numbers in this assay, from the lowest: compounds 1, 3 and 2 (each within the scatter of the next, the first and the last beyond it); then compound 4.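

In this assay, trifluoromethyl in place of tert-butyl gives a 4.4-fold higher number from compound 3 to compound 4 (0.64 log units; beyond the scatter), so this position on the six-membered aromatic ring responds to a full exchange of the group and not only to the trimming seen in a 2.2-fold higher number from compound 1 to compound 2 (0.33 log units; beyond the scatter). Both steps run towards a weaker inhibitor, and neither of the two measured changes at this position goes against that direction, although two steps on slightly different cores make a thin basis for any rule. The exchange also keeps much of what can be counted: each group has 4 heavy atoms, no ring and 0 hydrogen-bond donors or acceptors, so these counts alone do not settle the number in this assay, and nothing measured here on the two groups bears on why it moves.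

From the compounds shown here alone, it remains open whether the same exchange on the core of compound 1 would move the number in the same direction and by a similar amount. Also open, going by these compounds, is how this position would respond to a nitrile, a methoxy group, an amine or a carboxylic acid in place of tert-butyl.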